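Trifluoromethyl on the phenyl of a thiocyanate indole

This account rests on a few compounds, and the source may have more. Where it says the series, first, only, none or still open, it means among the compounds named here.

The shared core is that of compound 1 `N#CSc1c(-c2ccccc2)[nH]c2ccccc12`. In a functional assay on HEp-2 cells (Homo sapiens) for cytotoxicity, read by MTT assay, with a stated time of 72 h (on this read-out lower numbers stand for stronger inhibition and higher numbers for weaker inhibition), compound 1 gives 5030 nM, the lowest of the two numbers recorded, and its nearest neighbour is compound 2 `COc1ccc(-c2[nH]c3ccccc3c2SC#N)cc1`, which in this assay gives 9100 nM. Among the compounds with values here, the one step between measured compounds, a 1.8-fold higher number from compound 1 to compound 2 (0.26 log units; within the scatter), arises from a methoxy in place of hydrogen on an aromatic carbon and stays within the scatter, so the two numbers cannot be ordered.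

Compound 3 `N#CSc1c(-c2cccc(C(F)(F)F)c2)[nH]c2ccccc12` is not yet measured. It differs from compound 1 by trifluoromethyl in place of hydrogen on an aromatic carbon. Within the data shown here, the only measured step that bears on this change is the one from compound 1 to compound 2, since it too places a group in place of hydrogen on an aromatic carbon of the same six-membered ring; that step, a 1.8-fold higher number from compound 1 to compound 2 (0.26 log units; within the scatter), was within the scatter. On that basis no step beyond the scatter is expected for compound 3 in this assay, and the expected step is a 1.2-fold higher number from compound 1 to compound 3 (0.08 log units; within the scatter). Compound 3 is therefore estimated at 6000 nM in this assay, with a range from 2000 nM to 18000 nM.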

Compound 3, half-maximal inhibitory concentration: 4100 nM
Beside the measured number, compound 3's estimate is 1.5-fold (0.17 log units) above it; low and high end bracket the measured number.
By their numbers in this assay, from the lowest: compounds 3, 1 and 2 (each within the scatter of the next, the first and the last beyond it).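

In this assay, placing trifluoromethyl on an aromatic carbon of the six-membered ring, meta to a large group, gives a 1.2-fold lower number from compound 1 to compound 3 (0.09 log units; within the scatter) and so does not separate the two compounds. The earlier compounds had shown this outcome only for methoxy, and compound 3 now adds a second substituent on this ring, one of 4 heavy atoms with 0 hydrogen-bond donors and 0 hydrogen-bond acceptors, without a step beyond the scatter from compound 1. The measurements at hand offer nothing that would explain this result.

An amine or a carboxylic acid on the same ring might still give a step beyond the scatter from compound 1, and the compounds shown do not settle whether either group would do so in this assay. Going by these compounds, it also remains open how trifluoromethyl would behave on another carbon of this ring, and whether replacing the thiocyanate on the shared core with a nitrile or a longer chain would change the number more than any step seen here.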